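This account rests on a few compounds, and the source may have more. Where it says the series, first, only, none or still open, it means among the compounds named here.

Measured so far:
compound 1 `C=C(C)Cn1cc(CO[C@H]2CC(=O)[C@@H]3OC[C@H]2O3)nn1`: 17200 nM
compound 2 `O=C1C[C@H](OCc2cc(-c3ccccc3)no2)[C@H]2CO[C@@H]1O2`: 16900 nM

Both numbers come from a functional assay on HT-29 cells (Homo sapiens) for cytotoxicity, read by MTT assay, with a stated time of 48 h; a lower number here means a stronger inhibitor, a higher number a weaker inhibitor. Of the two, that of compound 2 is nominally the smaller, yet compound 1 lies within the scatter of it, so the two are read as equal and neither is called the stronger. Compound 3 `O=C1C[C@H](OCc2cc(-c3ccc([N+](=O)[O-])cc3)no2)[C@H]2CO[C@@H]1O2` keeps the whole of compound 2 and differs in one place: nitro in place of hydrogen on an aromatic carbon, para to a large group. For the measured compounds named here, no measured pair in this set shows what such a change does, and the two measured values give no trend in this assay that could be extended to it. The expected step in this assay is therefore a 1.1-fold lower number from compound 2 to compound 3 (0.05 log units; within the scatter), none beyond the scatter in either direction. For compound 3 the estimate in this assay is 15000 nM, with a range from 5000 nM to 45000 nM.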

Compound 3, half-maximal inhibitory concentration: 19800 nM
Compound 3: the middle estimate sits 1.3-fold (0.12 log units) below what was measured; measured number inside the range.
By their numbers in this assay, from the lowest: compounds 2, 1 and 3 (each within the scatter of the next).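

First measured pair in the series: in this assay, nitro in place of hydrogen on an aromatic carbon, para to a large group, gives a 1.2-fold higher number from compound 2 to compound 3 (0.07 log units; within the scatter). Adding these 3 heavy atoms, with 2 hydrogen-bond acceptors, at this place on the six-membered aromatic ring therefore leaves compound 2 and compound 3 indistinguishable in this read-out, which the earlier compounds, differing from each other in more than one place, could not show. Nothing available bears on the reason for this result.

On these data alone, whether an amine or a carboxylic acid on the same aromatic carbon would move the number beyond the scatter remains open. Also open, as far as these compounds go, is whether a nitro group elsewhere on that ring would behave as it does here, since this single pair speaks for one place only.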